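From bromo to tert-butyl on a shared core

A few compounds are considered here, and "the series" means these few. Any claim that something is new, unique, unknown or untested is made for them only; others in the source may bear on it.

Measured so far in an ADME assay on Vero cells (Chlorocebus sabaeus) for cytotoxicity, read by resazurin assay, with a stated time of 3 days; on this read-out higher numbers stand for weaker inhibition and lower numbers for stronger inhibition:
compound 1 `CN(C)c1cc2[nH]c(C3CCCCC3)nc2cc1NC(=O)c1ccc(Br)cc1` gives > 100 ug/mL
compound 2 `O=C(CCc1ccccc1)Nc1cc2nc(C3CCCCC3)[nH]c2cc1N1CCCC1` gives > 100 ug/mL

Compound 1 stands at a limit: its value of > 100 ug/mL is the limit of this assay and not a number. Compound 2 likewise sits at a limit, with > 100 ug/mL in this assay. Both therefore share (the limit of > 100 ug/mL in this assay, at which 2 of the 2 values shown sit), so no difference between them can be read from these values.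

Compound 3 `CN(C)c1cc2[nH]c(C3CCCCC3)nc2cc1NC(=O)c1ccc(C(C)(C)C)cc1` has not yet been measured. It differs from compound 1 by tert-butyl in place of bromo on an aromatic carbon, in words tert-butyl in place of bromo on an aromatic carbon. Among the measured compounds shown here, no step between two measured compounds exists to guide the size of this change. Because compound 1 gives > 100 ug/mL, the step expected here, a number no higher from compound 1 to compound 3 (the limit leaves the size open), is none beyond the scatter. The estimate for compound 3 is therefore 100 ug/mL, with a range from 30 ug/mL to 200 ug/mL, and most likely again only a limit.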

Compound 3, half-maximal inhibitory concentration: > 100 ug/mL
Compound 3: no number, only a limit; the forecaster's own chance of this, stated with the estimate: 80%; the middle value sits exactly at the limit.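

Compound 1 and compound 3 both stand at a limit and not at a number, so no step between them can be read: the limit of > 100 ug/mL in this assay, at which 3 of the 3 values shown sit.

The compounds shown leave open whether tert-butyl in place of bromo changes the read-out at all, and at what concentration any of these three compounds would reach half-maximal inhibition.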